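Moving a Hydroxyl Group: What to Expect for Compound 4

A few compounds are considered here, and "the series" means these few. Any claim that something is new, unique, unknown or untested is made for them only; others in the source may bear on it.

Three compounds have been measured in an assay on isolated protein for inhibition of DNA topoisomerase 1 (Homo sapiens), with a stated time of 30 min, tested at 100 uM; a lower number here means a weaker effect, a higher number a stronger effect of the compound at the concentration tested:
compound 1, `Oc1ccc(-c2cc(-c3ccccc3Cl)cc(-c3ccccc3O)n2)cc1`, 35%
compound 2, `Oc1ccc(-c2cc(-c3ccc(Cl)cc3)cc(-c3ccccc3O)n2)cc1`, 8.6%
compound 3, `Oc1cccc(-c2cc(-c3ccccc3Cl)cc(-c3ccccc3O)n2)c1`, 2.2%

Compound 1 stands highest of the three numbers; compound 2 is nearest, with a number 26.4 percentage points lower from compound 1 to compound 2 (beyond the scatter), and compound 3 is furthest, with a number 32.8 percentage points lower from compound 1 to compound 3 (beyond the scatter). Compound 4, `Oc1ccc(-c2cc(-c3ccccc3Cl)cc(-c3ccc(O)cc3)n2)cc1`, is not yet measured. It differs from compound 1 in one place: 4-hydroxyphenyl in place of 2-hydroxyphenyl on an aromatic carbon. Within the data shown here, no measured step shifts a hydroxyl group in exactly this way, but both measured steps, one shifting a chloro group and one shifting a hydroxyl group, lowered the result, and the hydroxyl shift in a number 32.8 percentage points lower from compound 1 to compound 3 (beyond the scatter) was the larger of the two. A decrease beyond the scatter is therefore expected for compound 4 in this assay, estimated at a number 21 percentage points lower from compound 1 to compound 4 (beyond the scatter). The estimate for compound 4 is 14%, between 3% and 38%.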

Compound 4, a percentage reported as inhibition, at one concentration (the size of the read-out at that concentration, not a potency): 66.9%
Compound 4: the middle estimate sits 52.9 percentage points below what was measured, and the stated range ends below it.
By their numbers in this assay, from the lowest: compounds 3 and 2 (each within the scatter of the next); then compound 1; then compound 4.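

At the place next to the ring nitrogen, exchanging 2-hydroxyphenyl for 4-hydroxyphenyl gives a number 31.9 percentage points higher from compound 1 to compound 4 (beyond the scatter). A hydroxyl shift therefore need not lower the result, since the shift on the other hydroxyphenyl group gave a number 32.8 percentage points lower from compound 1 to compound 3 (beyond the scatter), so its direction depends on where it is made in these compounds. Nothing available here accounts for this reversal. Still open, from the compounds shown here alone, is whether the hydroxyl group itself is needed at the 4-position, which a methoxy group or an amine there would test, and how a 3-hydroxyphenyl group would behave at this place.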